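Swapping the amine cap on a spirocyclic amino acid

The source may hold more compounds than are shown below. What is called first, only, known or untested is meant among the compounds shown, and "the series" means these compounds.

Three compounds have been measured:
compound 1, `Cc1noc(C)c1S(=O)(=O)N[C@@H](CCC(=O)N1CCC2(CC1)CCN(c1ccncc1)CC2)C(=O)O`, gives 21 nM in a functional assay for inhibition, with Homo sapiens as the target; a lower number here means a stronger inhibitor, a higher number a weaker inhibitor;
compound 2, `N=C(N)c1ccc(N2CCC3(CCN(CCC(=O)O)CC3)CC2)cc1`, gives 1150 nM in this assay;
compound 3, `O=C(O)CCCCC(=O)N1CCC2(CC1)CCN(c1ccncc1)CC2`, gives 4540 nM in this assay.

Compound 1 therefore stands with the lowest number of the three, and both compound 2 and compound 3 lie beyond the scatter above it. Compound 4, `O=C(N[C@@H](CCC(=O)N1CCC2(CC1)CCN(c1ccncc1)CC2)C(=O)O)OCc1ccccc1`, is not yet measured; it differs from compound 1 by benzyloxycarbonyl in place of (3,5-dimethyl-1,2-oxazol-4-yl)sulfonyl on an amine nitrogen. Among the compounds with values here, no measured pair in this set shows the same change, so the expectation rests on compound 1 alone. A small step toward a higher number, or none beyond the scatter, is expected as a 2.1-fold higher number from compound 1 to compound 4 (0.33 log units; beyond the scatter). Compound 4 is thus estimated at 45 nM, within a range from 10 nM to 250 nM.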

Compound 4, half-maximal inhibitory concentration: 4580 nM
Compound 4: the middle estimate sits 100-fold (2.01 log units) below what was measured; measured number outside the range, above it.
By their numbers in this assay, from the lowest: compound 1; then compound 2; then compounds 3 and 4 (each within the scatter of the next).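

On the amine nitrogen of the shared core, the cap matters a great deal: benzyloxycarbonyl in place of (3,5-dimethyl-1,2-oxazol-4-yl)sulfonyl gives a 220-fold higher number from compound 1 to compound 4 (2.34 log units; beyond the scatter) in this assay. The two groups have the same count of heavy atoms, so that count alone does not set the outcome at this position. Nothing available bears on why the step is so large. Going by these compounds, it remains open whether the sulfonyl link or the five-membered aromatic ring accounts for the difference; a phenylsulfonyl or a benzoyl group on this nitrogen would separate the two.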